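A Single Number Anchors Compound 4

The source may hold more compounds than are shown below. What is called first, only, known or untested is meant among the compounds shown, and "the series" means these compounds.

Among the measured compounds shown here, in a functional assay on MIA PaCa-2 cells (Homo sapiens) for antiproliferative activity, read by MTT assay, with a stated time of 72 h (a lower number here means a stronger inhibitor, a higher number a weaker inhibitor), compound 1 `O=C1NC(O)(CCn2cnc3cc[nH]c3c2=O)C(OCc2ccccc2)=C1OCc1ccccc1` gives 36600 nM, the only true number among the three compounds tested so far. Compound 2 `O=C1O/C(=C\Cn2cnc3ccnc(Cl)c32)C(OCc2ccccc2)=C1OCc1ccccc1` gives > 100000 nM, which is a limit of the assay and not a number. Compound 3 `O=C1O/C(=C\Cn2cnc3c(Cl)c(F)nc(F)c32)C(OCc2ccccc2)=C1OCc1ccccc1` gives > 100000 nM, and this too is a limit.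

Compound 4 `Nc1nc(F)c(Cl)c2c1ncn2CCC1(O)NC(=O)C(OCc2ccccc2)=C1OCc1ccccc1` has not yet been measured. Its difference from compound 1 is this: a group of 12 heavy atoms (6 carbon, 4 nitrogen, 1 fluorine, 1 chlorine; one five-membered aromatic ring with 2 hetero atoms, one six-membered aromatic ring with 1 hetero atom) in place of a group of 10 heavy atoms (6 carbon, 3 nitrogen, 1 oxygen; one five-membered aromatic ring with 1 hetero atom, one six-membered aromatic ring with 2 hetero atoms), on a saturated chain carbon, two bonds along the chain from a saturated ring carbon. The rest of the structure stays the same, so only the group on the chain changes.

For the measured compounds named here, the one measured step between compounds that differ in a single place is a step that the two limits leave unreadable from compound 2 to compound 3. With both ends at a limit, it has no size that could be carried over to compound 4. Any expectation must therefore start from compound 1 at 36600 nM, with a wide margin on either side. No direction can be defended from these data, so no shift beyond the usual scatter is expected. The expected change is a 1.2-fold lower number from compound 1 to compound 4 (0.09 log units; within the scatter). For compound 4 the estimate is 30000 nM, with an expected range from 8000 nM to 100000 nM.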

Compound 4, half-maximal inhibitory concentration: > 100000 nM
Compound 4 ended at the assay's limit (the forecaster's own chance of this, stated with the estimate: 30%); middle value at least 3.3-fold (0.52 log units) from the limit.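

Among the compounds shown here, this is the first readable step at this place, on a saturated chain carbon, two bonds along the chain from a saturated ring carbon; the step between the two earlier limits cannot be read. In this assay, putting the group of 12 heavy atoms, with its fluorine and chlorine, in place of the group of 10 heavy atoms of compound 1 gives an at least 2.7-fold higher number from compound 1 to compound 4 (0.43 log units; beyond the scatter), so the shared core does not hold its activity whatever group sits here. The value of compound 4 is a limit and not a number, so the step has a smallest size but no known full size, and the same ceiling bounds most of this small set: the limit of > 100000 nM in this assay, at which 3 of the 4 values shown sit.

The two groups differ in their rings and in several atoms at once, so the compounds shown cannot say whether the fluorine, the chlorine or the ring atoms account for the step. Going by these compounds, whether a simple phenyl ring, a carboxylic acid or a longer chain at this place would give a true number, stronger or weaker than that of compound 1, also stays open.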